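The compounds below may be only part of what the source reports. "The series", "measured", "known", "first", "only" and "open" are said of these compounds alone.

Measured so far:
- compound 1, `CS(=O)(=O)c1cc(C(=O)N=C(N)N)c(Cl)cc1Oc1cccnc1`: 52 nM
- compound 2, `COc1cc(N2CCC(N)CC2)c(S(C)(=O)=O)cc1C(=O)N=C(N)N`: 73 nM

The two compounds share a core carrying the acylguanidine and the methylsulfonyl group and differ at two places. In a functional assay for inhibition of sodium/hydrogen exchanger (Oryctolagus cuniculus) (on this read-out higher numbers stand for weaker inhibition and lower numbers for stronger inhibition), compound 1 gives 52 nM and compound 2 gives 73 nM; the gap between these two numbers lies within the usual scatter, so the two compounds cannot be told apart on this assay. Within the data shown here, no single-point step between measured compounds is available.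

Compound 3, `CS(=O)(=O)c1cc(C(=O)N=C(N)N)c(Cl)cc1N1CCC(N)CC1`, has not been measured. It differs from compound 2 in one place: chloro in place of methoxy on an aromatic carbon. Compound 3 thus carries the chloro of compound 1 together with the 4-aminopiperidin-1-yl group of compound 2. Since compound 1 with its chloro gives 52 nM and compound 2 with its methoxy gives 73 nM, and these agree within the scatter, the step from compound 2 to compound 3 is expected to be small, in either direction, and most likely not beyond the scatter; the expected step is a 1.2-fold lower number from compound 2 to compound 3 (0.09 log units; within the scatter). For compound 3 the value in this assay is estimated at 60 nM, with a range from 20 nM to 180 nM.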

Compound 3, half-maximal inhibitory concentration: 20 nM
For compound 3 the middle estimate is 3.0-fold (0.48 log units) above the measured one; the range from low to high includes it.
By their numbers in this assay, from the lowest: compound 3; then compounds 1 and 2 (each within the scatter of the next).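

With the 4-aminopiperidin-1-yl group held constant, the aromatic carbon para to the methylsulfonyl group proves sensitive to its substituent: in this assay, chloro in place of methoxy gives a 3.7-fold lower number from compound 2 to compound 3 (0.56 log units; beyond the scatter), whereas the earlier pair changed two places at once and stayed within the scatter, hiding any contribution from either place. With the chloro held constant, the other place also responds on its own, as 4-aminopiperidin-1-yl in place of (pyridin-3-yl)oxy gives a 2.6-fold lower number from compound 1 to compound 3 (0.41 log units; beyond the scatter), so the near-equal values of the earlier pair do not mean that these two places are indifferent to change. Nothing available here bears on the origin of either step.

As far as these compounds go, each change rests on a single pair, so it remains open whether the preference for chloro over methoxy carries over to a core with (pyridin-3-yl)oxy in place of 4-aminopiperidin-1-yl. Also open, from the compounds shown here alone, is how fluoro, bromo or methyl on the same aromatic carbon would compare with chloro, and whether an open-chain amine such as 2-aminoethylamino could stand in for the 4-aminopiperidin-1-yl group.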